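The source may report more compounds than this note shows. Statements on the series, on what has been measured and on what is new or still open speak of the compounds shown alone.

Compound 1 `Cc1c(C(=O)Nc2ccc(F)c(F)c2)sc(N)c1C#N` — > 100000 nM
Compound 2 `Cc1c(C(=O)Nc2ccccc2)sc(N)c1C(=O)Nc1ccccc1` — > 100000 nM

Both measured compounds were tested in an ADME assay on HepG2 cells (Homo sapiens) for cytotoxicity, read by XTT assay, with a stated time of 2 days; on this read-out lower numbers stand for higher toxicity in this test and higher numbers for lower toxicity in this test. Compound 1 gives > 100000 nM, which is a limit of the assay. Compound 2 gives > 100000 nM, also a limit. For the measured compounds named here, compound 2 therefore stands at the limit of > 100000 nM in this assay, at which 2 of the 2 values shown sit, and since every value shown is such a limit, no step between measured compounds can be read from these numbers.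

Compound 3 `Cc1c(C(=O)Nc2ccc(F)c(F)c2)sc(N)c1C(=O)Nc1ccccc1` has not yet been measured in this assay. It differs from compound 2 by 3,4-difluorophenyl in place of phenyl on an amide-type nitrogen. Compound 1 already carries this 3,4-difluorophenyl group on an amide-type nitrogen and sits at the same limit, so the expectation for this assay is a step that the limit leaves unreadable from compound 2 to compound 3, that is, none beyond the scatter. Compound 3 is therefore expected to give 150000 nM, with a range from 70000 nM to 400000 nM, and most probably the assay would again report only a limit.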

Compound 3, half-maximal cytotoxic concentration: 26000 nM
Estimate against measurement, compound 3: 5.8-fold (0.76 log units) above, outside the stated range (below it).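

In this assay, for the compounds shown here, 3,4-difluorophenyl in place of phenyl on an amide-type nitrogen gives an at least 3.8-fold lower number from compound 2 to compound 3 (0.58 log units; beyond the scatter) and so shows that the number responds to a change at this place, which the earlier compounds could not show. Phenylcarbamoyl in place of cyano on an aromatic carbon, with the 3,4-difluorophenyl group kept, gives an at least 3.8-fold lower number from compound 1 to compound 3 (0.58 log units; beyond the scatter) and so shows that this group alone does not bring the number down: among these compounds, a measurable value appears only where 3,4-difluorophenyl and phenylcarbamoyl occur together. Both steps give only a smallest possible size because each starts from a limit: the limit of > 100000 nM in this assay, at which 2 of the 3 values shown sit.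

As far as these compounds go, it remains open whether a phenyl ring with a single fluorine, or a chlorophenyl or methoxyphenyl group, would lower the number in the same way. From the compounds shown here alone, it is also open how a carboxylic acid or an ethyl ester would behave in place of the phenylcarbamoyl group.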